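Para-substituted phenoxy variants in the antiproliferative series

The source may hold more compounds than are shown below. What is called first, only, known or untested is meant among the compounds shown, and "the series" means these compounds.

Measured compounds:
compound 1 `Cc1nn(C)c(Oc2cccc(F)c2)c1/C=N\CCCCCOc1cc2oc(=O)cc(C)c2cc1Cl`: 9870 nM
compound 2 `Cc1nn(C)c(Oc2ccc(F)cc2)c1/C=N\CCCCCOc1cc2oc(=O)cc(C)c2cc1Cl`: > 25000 nM

For the measured compounds named here, in a functional assay on U-87MG ATCC cells for antiproliferative activity against U-87 MG (Homo sapiens), read by MTT assay, with a stated time of 72 h (on this read-out lower numbers stand for stronger inhibition and higher numbers for weaker inhibition), compound 1 gives 9870 nM, the only numerical value in the set. For compound 2 the result is a limit of the assay, > 25000 nM, as noted in the limit of > 25000 nM in this assay, at which 1 of the 2 values shown sits. Going by the values given here, the one measured step, an at least 2.5-fold higher number from compound 1 to compound 2 (0.40 log units; beyond the scatter), moves the fluorine on the phenoxy group and weakens the result beyond the scatter.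

Compound 3 `Cc1nn(C)c(Oc2ccc(Cl)cc2)c1/C=N\CCCCCOc1cc2oc(=O)cc(C)c2cc1Cl` has not yet been measured in this assay. Its difference from compound 1 is 4-chlorophenyl in place of 3-fluorophenyl on an oxygen on an aromatic ring. Like compound 2 it carries a single halogen at the 4-position of the phenoxy ring, and the only relevant step, from compound 1 to compound 2, went toward weaker inhibition. The change to chlorine is not covered by any measured pair, so the expectation rests on that single step alone.

Compound 3 is therefore expected to sit weaker than compound 1, with a step of a 2.2-fold higher number from compound 1 to compound 3 (0.35 log units; beyond the scatter), and may well return only a limit; the estimate for compound 3 is 22000 nM, between 8000 nM and 60000 nM.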

Compound 3, half-maximal inhibitory concentration: 18700 nM
The estimate for compound 3 lay 1.2-fold (0.07 log units) above the measured number; measured number inside the range.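

The 4-chlorophenyl group on this oxygen gives a readable number in this assay, and the step, a 1.9-fold higher number from compound 1 to compound 3 (0.28 log units; within the scatter), does not separate it from 3-fluorophenyl, so the clear weakening in the step of an at least 2.5-fold higher number from compound 1 to compound 2 (0.40 log units; beyond the scatter) does not carry over to every 4-halophenyl group in this series. Chloro in place of fluoro on this aromatic carbon gives an at least 1.3-fold lower number from compound 2 to compound 3 (0.12 log units; that floor lies within the scatter), so this pair resolves no difference between the two halogens, although the true gap could be larger than this floor. Compound 2 remains a limit and not a number: the limit of > 25000 nM in this assay, at which 1 of the 3 values shown sits.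

The compounds shown leave open how 3-chlorophenyl on this oxygen would read against compound 1 and compound 3, a comparison that would separate the identity of the halogen from its place on the ring. Also open, going by these compounds, is how an unsubstituted phenyl, a phenyl group carrying an amine or a methoxy group, or a longer chain to the shared core would read in this assay.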